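Pyridin-4-yl Replaces Thiophen-3-yl on the Shared Core

A few compounds are considered here, and "the series" means these few. Any claim that something is new, unique, unknown or untested is made for them only; others in the source may bear on it.

In a functional assay on HCT-15 cells (Homo sapiens) for cytotoxicity, read by ELISA, with a stated time of 2 days (a lower number here means a stronger inhibitor, a higher number a weaker inhibitor), compound 1 `Oc1cccc(-c2cc(-c3ccccc3)cc(-c3ccccc3)n2)c1` gives 9950 nM and compound 2 `Oc1cccc(-c2cc(-c3ccccc3)cc(-c3ccsc3)n2)c1` gives 7660 nM with the two values within the scatter of each other. Compound 3 `Oc1cccc(-c2cc(-c3ccccc3)cc(-c3ccncc3)n2)c1` carries pyridin-4-yl in place of thiophen-3-yl on an aromatic carbon. Going by the values given here, the one measured step at this carbon is a 1.3-fold lower number from compound 1 to compound 2 (0.11 log units; within the scatter) and no measured compound yet carries pyridin-4-yl there. The expected move in this assay is therefore a 1.1-fold higher number from compound 2 to compound 3 (0.05 log units; within the scatter) and no shift beyond the scatter is expected. Compound 3 is estimated at 8500 nM with an expected range of 3000 nM to 25000 nM in this read-out.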

Compound 3, half-maximal inhibitory concentration: 27400 nM
Compound 3: middle estimate off by 3.2-fold (0.51 log units), on the low side; measured number above the stated range.
By their numbers in this assay, from the lowest: compounds 2 and 1 (each within the scatter of the next); then compound 3.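

Phenyl and thiophen-3-yl could not be told apart at this carbon next to the ring nitrogen, but pyridin-4-yl moves the number beyond the scatter in this assay. Against thiophen-3-yl the change gives (a 3.6-fold higher number from compound 2 to compound 3 (0.55 log units; beyond the scatter)), and against phenyl it gives (a 2.8-fold higher number from compound 1 to compound 3 (0.44 log units; beyond the scatter)). The position therefore responds to the group it carries, though both steps are modest. No measurement shown here bears on what lies behind this rise. As far as these compounds go, whether pyridin-3-yl or an aminophenyl group at this carbon would shift the number in the same direction remains open.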